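A hydroxy in place of a fluoro

The source may report more compounds than this note shows. Statements on the series, on what has been measured and on what is new or still open speak of the compounds shown alone.

Compound 1 `C=C1C=CC(=O)[C@@H]2[C@H](Cc3cc(OC)c(OC)c(OC)c3)CC[C@H]12`: > 1000 nM (a limit)
Compound 2 `C=C1C=CC(=O)[C@@H]2[C@H](Cc3ccc(F)c(F)c3)CC[C@H]12`: 222 nM

Among the measured compounds shown here, in a functional assay on A-375 cells (Homo sapiens) for antiproliferative activity, with a stated time of 72 h (a higher number here means a weaker inhibitor, a lower number a stronger inhibitor), compound 2 gives 222 nM, the only actual number so far. Compound 1 reaches only a limit of the assay, > 1000 nM.

Compound 3 `C=C1C=CC(=O)[C@@H]2[C@H](Cc3ccc(O)c(F)c3)CC[C@H]12` differs from compound 2 by one exchange: hydroxy in place of fluoro on an aromatic carbon. This puts hydroxy in place of fluoro on an aromatic carbon. For the measured compounds named here, no measured pair shows this change, so the expectation is tentative: a modest weakening, perhaps little beyond the scatter. The estimated step is a 1.6-fold higher number from compound 2 to compound 3 (0.20 log units; within the scatter). For compound 3 the expected value is 350 nM, with an estimated range of 100 nM to 1000 nM.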

Compound 3, half-maximal inhibitory concentration: 98.4 nM
Compound 3: the middle estimate sits 3.6-fold (0.55 log units) above what was measured; measured number outside the range, below it.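

In this assay, hydroxy in place of fluoro, on an aromatic carbon ortho to a fluoro group and para to a large group, gives a 2.3-fold lower number from compound 2 to compound 3 (0.35 log units; beyond the scatter) and so a modest gain beyond the scatter. This position therefore tolerates a group with a hydrogen-bond donor and acceptor, and the exchange strengthens rather than weakens the compound. Nothing shown here accounts for this gain. Still open, as far as these compounds go, is whether an amine or a carboxylic acid on this carbon would do as well, and whether the gain would survive removal of the remaining fluoro group.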